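Swapping a fused dioxin for two methoxy groups

A few compounds are considered here, and "the series" means these few. Any claim that something is new, unique, unknown or untested is made for them only; others in the source may bear on it.

Compound 2 `CC(C)N(Cc1cccc(OCCCCCC(=O)O)c1)C(=O)c1ccc(-c2ccc3c(c2)OCCO3)cc1` is the starting point of this step. In an ADME assay on Raji cells (Homo sapiens) for cytotoxicity, read by CellTiter-Glo and resazurin assay, with a stated time of 72 h (a lower number here means that less compound is needed, a higher number that more compound is needed for the effect), compound 2 gives > 21900 nM, which is a limit of the assay rather than a number. Compound 1 `CC(C)COc1cccc(-c2ccc(C(=O)N(Cc3cccc(OCCCCCC(=O)O)c3)C(C)C)cc2)c1` differs from compound 2 in one place, where 3-(isobutoxy)phenyl stands in place of 2,3-dihydro-1,4-benzodioxin-6-yl. In this assay compound 1 gives > 26000 nM, again a limit. The step between them, a step that the two limits leave unreadable from compound 1 to compound 2, cannot be read in size because the limit of > 21900 nM in this assay, at which 1 of the 2 values shown sits, and the limit of > 26000 nM in this assay, at which 1 of the 2 values shown sits, are where the two values sit. Compound 3 `COc1cc(OC)cc(-c2ccc(C(=O)N(Cc3cccc(OCCCCCC(=O)O)c3)C(C)C)cc2)c1` has not yet been measured; it carries 3,5-dimethoxyphenyl in place of 2,3-dihydro-1,4-benzodioxin-6-yl on an aromatic carbon. Going by the values given here, the one measured step bears on it only by showing that an exchange of a group at this same place left both compounds at a limit, so no change beyond the scatter is expected in this assay, in either direction. Compound 3 is therefore estimated at 30000 nM, between 12000 nM and 120000 nM, most likely reported once more as a limit. The estimated step from compound 2 to compound 3, a step that the limit leaves unreadable from compound 2 to compound 3, is expected to stay within the scatter.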

Compound 3, half-maximal effective concentration: > 26000 nM
Compound 3 ended at the assay's limit (the forecaster's own chance of this, stated with the estimate: 85%); the middle value is on the limit's open side.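

In this assay compound 3 gives > 26000 nM, which is a limit of the assay and not a number. Going by these compounds alone, compound 1, compound 2 and compound 3 all sit at limits, so no step among them can be read. The compounds shown leave open what concentration of any of the three gives the effect in this assay.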